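Sulfur substituent and growth inhibition: working notes

The source may report more compounds than this note shows. Statements on the series, on what has been measured and on what is new or still open speak of the compounds shown alone.

Measured so far:
- compound 1 `Cc1ccc(SCc2ccc(/C=C/C(=O)Nc3ccccc3N)cc2)cc1`: 21.7%
- compound 2 `Nc1ccccc1NC(=O)/C=C/c1ccc(CSCCc2ccccc2)cc1`: 3.57%

In a functional assay on HeLa cells (Homo sapiens) for inhibition, read by CCK-8 assay, with a stated time of 72 h, tested at 8 uM (a lower number here means less inhibition of growth, a higher number more inhibition of growth at the concentration tested), compound 2 holds the lower of the two numbers. Next is compound 3 `CC(C)(C)c1ccc(SCc2ccc(/C=C/C(=O)Nc3ccccc3N)cc2)cc1`, with this change: 4-(tert-butyl)phenyl in place of phenethyl on a sulfur. Phenethyl thus gives way to 4-(tert-butyl)phenyl on a sulfur. Among the compounds with values here, only one measured step bears on this, a number 18.1 percentage points lower from compound 1 to compound 2 (beyond the scatter), where phenethyl replaced 4-methylphenyl on a sulfur. Restoring a substituted phenyl on the sulfur is expected to reverse that step at a similar size, beyond the scatter: a number 18.4 percentage points higher from compound 2 to compound 3 (beyond the scatter). The estimated value for compound 3 is 22%, with an expected range of 8% to 45%.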

Compound 3, percent growth inhibition at one concentration: 9.8%
For compound 3 the middle estimate is 12.2 percentage points above the measured one; low and high end bracket the measured number.
By their numbers in this assay, from the lowest: compounds 2 and 3 (each within the scatter of the next); then compound 1.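

In this assay, a substituted phenyl on the sulfur does not by itself restore growth inhibition: the change gives a number 6.2 percentage points higher from compound 2 to compound 3 (within the scatter), so 4-(tert-butyl)phenyl and phenethyl are not separated here. The group on the aromatic ring also counts, since tert-butyl in place of methyl on an aromatic carbon gives a number 11.9 percentage points lower from compound 1 to compound 3 (beyond the scatter), a change that lies beyond the scatter. Nothing at hand bears on the reason for either result.

Open, going by these compounds, is how a plain phenyl on the sulfur would read. Also open, on these data alone, is how a methoxy group or a chlorine in place of methyl on the aromatic carbon would read.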